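The compounds below may be only part of what the source reports. "The series", "measured", "known", "first", "only" and "open" are said of these compounds alone.

Compound 1 `O=[N+]([O-])c1ccc(Nc2ccccc2)c2nonc12` carries a phenyl on a nitrogen on an aromatic ring of a small nitro-bearing core. In an assay on isolated protein for inhibition of Myc proto-oncogene protein (Homo sapiens), read by mobility shift assay, tested at 100 uM (a lower number here means less inhibition, a higher number more inhibition at the concentration tested (going by the name of the read-out)), compound 1 gives 2%. Among the compounds with values here, only one other compound stands beside it: compound 2 `O=[N+]([O-])c1ccc(NC2CCCCC2)c2nonc12` has cyclohexyl in place of that phenyl, and in this assay compound 2 gives 11%. The step of a number 9 percentage points higher from compound 1 to compound 2 (within the scatter) stays within the usual scatter, so the two cannot be told apart on these numbers.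

Compound 3 `Cc1ccccc1Nc1ccc([N+](=O)[O-])c2nonc12` differs from compound 1 by methyl in place of hydrogen on an aromatic carbon. Within the data shown here, no measured step touches the phenyl ring in this way; the single step available, from compound 1 to compound 2, exchanges the whole ring and still moves nothing beyond the scatter, so it gives no ground to expect a shift here. Compound 3 is therefore expected to give 3%, within a range from -8% to 15%. The estimated step of a number 1 percentage points higher from compound 1 to compound 3 (within the scatter) is expected to remain within the scatter.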

Compound 3, a percentage reported as inhibition, at one concentration (the size of the read-out at that concentration, not a potency): 11%
Compound 3: middle estimate off by 8 percentage points, on the low side; measured number inside the range.
By their numbers in this assay, from the lowest: compounds 1, 2 and 3 (each within the scatter of the next).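

Methyl in place of hydrogen on an aromatic carbon, ortho to a large group, is the first change here made on the phenyl ring itself rather than to the whole ring, and it gives a number 9 percentage points higher from compound 1 to compound 3 (within the scatter) in this assay. Within the data shown here, at this place, then, the added methyl produces no step that can be told from the scatter, so the result shows no gain or loss from this change. Nothing available explains this result or shows how the methyl acts at this place.

As far as these compounds go, whether a chlorine, a methoxy, a carboxylic acid or an amine at this same place would give a number beyond the scatter stays open. So does whether a methyl on another carbon of the phenyl ring would behave like this one.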